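The source may report more compounds than this note shows. Statements on the series, on what has been measured and on what is new or still open speak of the compounds shown alone.

Compound 2 `CC(C)(C)c1ccc(CNCCCNS(=O)(=O)c2cc(C(F)(F)F)cc(C(F)(F)F)c2)cc1` is the starting point here. Among the compounds with values here, in a functional assay on Capan-2 cells (Homo sapiens) for inhibition, read by MTT assay, with a stated time of 72 h (on this read-out lower numbers stand for stronger inhibition of growth and higher numbers for weaker inhibition of growth), compound 2 gives 2100 nM, the lowest of the three numbers measured so far. Compound 1 `O=S(=O)(NCCCNCc1ccc(Cl)cc1)c1cc(C(F)(F)F)cc(C(F)(F)F)c1` gives 2700 nM in this assay, and the step of a 1.3-fold lower number from compound 1 to compound 2 (0.11 log units; within the scatter) is one that a repeat measurement could just as well have erased. Compound 3 `O=S(=O)(NCCCNCc1cccc(Cl)c1)c1cc(C(F)(F)F)cc(C(F)(F)F)c1` gives 8000 nM in this assay; the steps of a 3.0-fold higher number from compound 1 to compound 3 (0.47 log units; beyond the scatter) and a 3.8-fold higher number from compound 2 to compound 3 (0.58 log units; beyond the scatter) are the only ones here that clearly move the number.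

Compound 4 `O=S(=O)(NCCCNCc1ccc(-c2ccccc2)cc1)c1cc(C(F)(F)F)cc(C(F)(F)F)c1` differs from compound 2 in one place: phenyl in place of tert-butyl on an aromatic carbon. Within the data shown here, only one measured step touches this same position, the exchange of chloro for tert-butyl in a 1.3-fold lower number from compound 1 to compound 2 (0.11 log units; within the scatter), and it stayed within the scatter. Among the measured compounds shown here, no measured compound carries a phenyl at this position, so the data give no direct guide to that group. The expectation is therefore a small step, a 1.1-fold lower number from compound 2 to compound 4 (0.02 log units; within the scatter), not clearly beyond the scatter in either direction. Compound 4 is estimated to give 2000 nM in this assay, within a range from 700 nM to 6000 nM.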

Compound 4, concentration for 50% growth inhibition: 2200 nM
For compound 4 the middle estimate is 1.1-fold (0.04 log units) below the measured one; low and high end bracket the measured number.
By their numbers in this assay, from the lowest: compounds 2, 4 and 1 (each within the scatter of the next); then compound 3.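

In this assay, the exchange puts a ring at this position, with six carbons in place of the four in tert-butyl, and the result is a 1.0-fold higher number from compound 2 to compound 4 (0.02 log units; within the scatter). The comparison with chloro reads the same way, with a 1.2-fold lower number from compound 1 to compound 4 (0.09 log units; within the scatter). Chloro, tert-butyl and phenyl on this aromatic carbon therefore cannot be told apart on this read-out, so a whole aromatic ring here produces no step that stands clear of the scatter, just as tert-butyl did not.

As far as these compounds go, whether a different kind of group at this position, such as an amine or a carboxylic acid, would also leave the number within the scatter remains open. No available evidence explains why these three groups give numbers that cannot be told apart.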